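Cytotoxicity on fibroblasts: swapping iodo for methylsulfanylphenyl

The source may report more compounds than this note shows. Statements on the series, on what has been measured and on what is new or still open speak of the compounds shown alone.

Compound 1, `O=C(CCc1cccc2c1B(O)OC2)NC1CCCCC1`, gives > 100000 nM in an ADME assay on WI-38 cells (Homo sapiens) for cytotoxicity, read by MTT assay, with a stated time of 72 h (on this read-out lower numbers stand for stronger inhibition and higher numbers for weaker inhibition), which is a limit of the assay and not a number. Compound 2, `O=C(CCc1cccc2c1B(O)OC2)Nc1ccc(Cl)cc1`, gives > 100000 nM in this assay, again a limit. Compound 3, `O=C(CCc1cccc2c1B(O)OC2)Nc1cccc(I)c1`, gives 71000 nM in this assay.

Among the measured compounds shown here, compound 3 therefore holds the only number among the three, the other two values being limits (the limit of > 100000 nM in this assay, at which 2 of the 3 values shown sit). Compound 4, `CSc1cccc(-c2cccc(NC(=O)CCc3cccc4c3B(O)OC4)c2)c1`, differs from compound 3 in one place: 3-(methylsulfanyl)phenyl in place of iodo on an aromatic carbon.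

For the measured compounds named here, no measured step exchanges an iodo for an aryl group, so none bears directly on this change. The steps that end at compound 3 are an at least 1.4-fold lower number from compound 1 to compound 3 (0.14 log units; that floor lies within the scatter) and an at least 1.4-fold lower number from compound 2 to compound 3 (0.14 log units; that floor lies within the scatter), and a step that the two limits leave unreadable from compound 1 to compound 2; all of them concern the group on the amide-type nitrogen, not the ring carbon changed here, and their sizes are not readable. The expectation for compound 4 is thus no step beyond the scatter, a 1.2-fold lower number from compound 3 to compound 4 (0.07 log units; within the scatter). Compound 4 is estimated at 60000 nM in this assay, between 20000 nM and 150000 nM.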

Compound 4, half-maximal inhibitory concentration: 2000 nM
Compound 4: the middle estimate sits 30-fold (1.48 log units) above what was measured; the whole stated range lies above it.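

In this assay, among the compounds shown here, this change brings a 36-fold lower number from compound 3 to compound 4 (1.55 log units; beyond the scatter), the only step in this set that can be read as beyond the scatter. The earlier compounds shown here differ only in the group on the amide-type nitrogen, and their steps cannot be read: the limit of > 100000 nM in this assay, at which 2 of the 4 values shown sit. This aromatic carbon is therefore the first place where a change clearly moves the read-out, with the 3-(methylsulfanyl)phenyl group giving stronger inhibition than iodo.

Still open, going by these compounds, is whether the added six-membered aromatic ring or the methylsulfanyl group on it accounts for the step, and a plain phenyl group at this carbon would separate the two. Also open, on these data alone, is whether a small group at the same carbon, such as an amine, would move the number at all.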